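The source may hold more compounds than are shown below. What is called first, only, known or untested is meant among the compounds shown, and "the series" means these compounds.

Measured compounds:
compound 1 `COc1cccc(CNc2ncnc3c2ncn3[C@@H]2O[C@H](CO)[C@@H](O)[C@H]2O)c1OC` — > 166000 nM
compound 2 `OC[C@H]1O[C@@H](n2cnc3c(NCc4cc(F)cc(F)c4)ncnc32)C(O)C1O` — > 166000 nM
compound 3 `COc1cc(CNc2ncnc3c2ncn3[C@@H]2O[C@H](CO)[C@@H](O)[C@H]2O)cc(OC)c1O` — > 166000 nM

All three were tested in a functional assay on K562 cells (Homo sapiens) for antiproliferative activity, with a stated time of 72 h; on this read-out higher numbers stand for weaker inhibition and lower numbers for stronger inhibition. For compound 1 the value > 166000 nM is a limit of the assay and not a number. Compound 2 likewise gives only a limit, > 166000 nM. Compound 3 too gives only a limit, > 166000 nM. Compound 1 therefore stands where everything measured here stands, at the limit of > 166000 nM in this assay, at which 3 of the 3 values shown sit, and no measured step between any pair of these compounds can be stated.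

Compound 4 `OC[C@H]1O[C@@H](n2cnc3c(NCc4ccccc4OC(F)F)ncnc32)[C@H](O)[C@@H]1O` differs from compound 1 in one place: 2-(difluoromethoxy)phenyl in place of 2,3-dimethoxyphenyl on a saturated chain carbon bound to a nitrogen on an aromatic ring. Among the compounds with values here, with no measured step to draw on, and every measured value sitting at a limit, the step that the limit leaves unreadable from compound 1 to compound 4 is expected to be no change beyond the scatter, with the most likely outcome being another limit rather than a number. Compound 4 is accordingly estimated to give 200000 nM, with a range from 50000 nM to 600000 nM.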

Compound 4, half-maximal inhibitory concentration: > 166000 nM
Compound 4 ended at the assay's limit; the forecaster's own chance of this, stated with the estimate: 80%; the middle value does not contradict the limit.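

In this assay compound 4 gives > 166000 nM, a limit of the assay and not a number. No step from compound 1 to compound 4 can be read, as both stop at a limit: the limit of > 166000 nM in this assay, at which 4 of the 4 values shown sit.

The compounds shown leave open whether any change to the shared core would give a measurable value in this assay.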